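From carboxy to iodo in one pair of compounds

The source may report more compounds than this note shows. Statements on the series, on what has been measured and on what is new or still open speak of the compounds shown alone.

Measured in an ADME assay on J774 cells (Mus musculus) for cytotoxicity (a lower number here means that less compound is needed, a higher number that more compound is needed for the effect), all as limits of the assay:
- compound 1 `COC(=O)c1c[nH]c2cc(F)ccc2c1=O` gives > 20000 nM as its result
- compound 2 `CCCCc1cc2c(=O)c(C(=O)O)c[nH]c2cc1OCCOc1ccccc1` gives > 20000 nM as its result

Compound 2 stands at (> 20000 nM), which is a limit of the assay and not a number. For the measured compounds named here, that reading is (the limit of > 20000 nM in this assay, at which 2 of the 2 values shown sit), so no measured step is available as a guide.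

Compound 3 `CCCCc1cc2c(=O)c(I)c[nH]c2cc1OCCOc1ccccc1` has not yet been measured. It carries iodo in place of carboxy on an aromatic carbon.

With only limits to go on, the expected change in this assay is modest and towards a lower number, and the estimated step is (an at least 1.3-fold lower number from compound 2 to compound 3 (0.12 log units; that floor lies within the scatter)). Compound 3 is expected near (15000 nM), with an estimated range from 5000 nM up to 40000 nM for repeat measurements, and the assay may again report only a limit.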

Compound 3, half-maximal effective concentration: > 10000 nM
Compound 3: only a limit was reported; the forecaster's own chance of this, stated with the estimate: 55%; the middle value does not contradict the limit.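

In this assay, for the compounds shown here, the results for compound 2 and compound 3 are both limits of the assay, so no step between them can be read. The compounds shown leave open whether iodo in place of carboxy on an aromatic carbon shifts this read-out at all, and in which direction.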